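Chloro to bromo on a thioamide: what to expect

A few compounds are considered here, and "the series" means these few. Any claim that something is new, unique, unknown or untested is made for them only; others in the source may bear on it.

Measured compounds:
compound 1, `COc1cc(Cl)ccc1C(=O)Nc1cc(Cl)ccc1O`, 87000 nM
compound 2, `COc1cc(Cl)ccc1C(=O)Nc1cc(Br)ccc1O`, 5630 nM
compound 3, `COc1cc(Cl)ccc1C(=S)Nc1ccc(Cl)cc1O`, 5110 nM

All three were tested in a functional assay on HepG2 cells (Homo sapiens) for cytotoxicity, with a stated time of 24 h; on this read-out higher numbers stand for weaker inhibition and lower numbers for stronger inhibition. Compound 1 gives 87000 nM, and compound 2, which differs from it by bromo in place of chloro on an aromatic carbon, gives 5630 nM, a step of a 15-fold lower number from compound 1 to compound 2 (1.19 log units; beyond the scatter). Compound 3 gives 5110 nM; the difference between the core of compound 3 and the core of compound 1 is not broken down here, and its value lies within the scatter of that of compound 2.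

Compound 4, `COc1cc(Cl)ccc1C(=S)Nc1ccc(Br)cc1O`, is not yet measured. It differs from compound 3 by bromo in place of chloro on an aromatic carbon. This is the same kind of change as from compound 1 to compound 2, but not the same: there the place was meta to a large group and para to a hydroxy group, here it is meta to a hydroxy group and para to a large group. Among the measured compounds shown here, only one earlier example exists, so the expected step for compound 4 is taken as smaller than the earlier one, a 2.0-fold lower number from compound 3 to compound 4 (0.31 log units; beyond the scatter), resting on a 15-fold lower number from compound 1 to compound 2 (1.19 log units; beyond the scatter). Compound 4 is therefore estimated at 2500 nM, between 800 nM and 8000 nM.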

Compound 4, half-maximal inhibitory concentration: 3880 nM
Beside the measured number, compound 4's estimate is 1.6-fold (0.19 log units) below it, and the stated range covers the measured number.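

In this assay, bromo in place of chloro on an aromatic carbon gives a 1.3-fold lower number from compound 3 to compound 4 (0.12 log units; within the scatter) and so shows no change on this core that can be told apart from the ordinary spread of repeat measurements. Set beside the earlier step, the same swap does not carry over in size from one core to the other: the same change on two cores in this assay, a 15-fold lower number (1.19 log units; beyond the scatter) from compound 1 to compound 2 and a 1.3-fold lower number (0.12 log units; within the scatter) from compound 3 to compound 4, 12-fold (1.07 log units) apart, beyond the scatter of two such steps

What this does not show is which difference between the two pairs lies behind that gap: one pair has a carbonyl and the other a thioamide, the halogen also sits in a different place, and two pairs give no general rule.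

The compounds shown leave open whether the large step belongs to the carbonyl or to the place of the halogen, which would take compounds differing in only one of these to settle. They also leave open how other groups in the same place, such as fluoro, methyl or an amine, would read on either core.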